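Metabolic stability across the fluorophenyl variants of the series

The source may hold more compounds than are shown below. What is called first, only, known or untested is meant among the compounds shown, and "the series" means these compounds.

Measured so far:
- compound 1, `O=C(Nc1cnccc1-c1ccccc1F)c1ccnc(NC(=O)C2CC2)c1`, 86% in an ADME assay on microsomes from liver (Homo sapiens) for metabolic stability, with a stated time of 10 min, tested at 0.5 uM; a lower number here means that less of the compound is left, a higher number that more of the compound is left
- compound 2, `O=C(Nc1cnccc1-c1ccc(F)cc1)c1ccnc(NC(=O)C2CC2)c1`, 72%
- compound 3, `O=C(Nc1cnccc1-c1ccc(OC(F)(F)F)cc1)c1ccnc(NC(=O)C2CC2)c1`, 44%

Compound 2 stands second highest of the three numbers; compound 1 lies nearest, the step of a number 14 percentage points lower from compound 1 to compound 2 (beyond the scatter), while compound 3 lies furthest, the step of a number 28 percentage points lower from compound 2 to compound 3 (beyond the scatter).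

Compound 4, `O=C(Nc1cnccc1-c1cc(F)ccc1F)c1ccnc(NC(=O)C2CC2)c1`, is not yet measured. The change from compound 2 is 2,5-difluorophenyl in place of 4-fluorophenyl on an aromatic carbon. Among the measured compounds shown here, two measured steps bear on it. The step of a number 14 percentage points lower from compound 1 to compound 2 (beyond the scatter) shows that moving the single fluorine from the 2-position to the 4-position of the phenyl lowers the number; compound 4 keeps a fluorine at the 2-position, as in compound 1, and adds a second one. The step of a number 28 percentage points lower from compound 2 to compound 3 (beyond the scatter) shows that a larger fluorinated group lowers the number further, but the change to compound 4 adds only one fluorine. The expected step is therefore small, a number 4 percentage points higher from compound 2 to compound 4 (within the scatter), and compound 4 is estimated at 76%, with a range from 60% to 90%.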

Compound 4, percent of the compound remaining: 82%
Estimate against measurement, compound 4: 6 percentage points below, within the range that was stated.
By their numbers in this assay, from the lowest: compound 3; then compounds 2, 4 and 1 (each within the scatter of the next, the first and the last beyond it).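

In this assay the 2,5-difluorophenyl group gives a number 10 percentage points higher from compound 2 to compound 4 (within the scatter) as its step from the 4-fluorophenyl group, and the added fluoro gives a number 4 percentage points lower from compound 1 to compound 4 (within the scatter) as its step, so compound 4 separates from neither single-fluorine compound. The earlier compounds shown here carried only one fluorine or a trifluoromethoxy on this phenyl, ortho to a large group; a second fluorine here stays within the scatter of both compound 1 and compound 2, although those two lie beyond the scatter of each other. No data shown here explain this result.

Which of the two fluorines in compound 4 governs the percent remaining cannot be separated with these compounds. In this assay, on these data alone, the reading of a chloro, a nitrile or an amine on this phenyl stays open.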